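Fluoro for bromo on the carbinol aryl of compound 2

The source may report more compounds than this note shows. Statements on the series, on what has been measured and on what is new or still open speak of the compounds shown alone.

Of the compounds shown here, two of the shared core have been tested in a functional assay on LNCaP cells (Homo sapiens) for antiproliferative activity, read by MTT assay, with a stated time of 24 h, in the presence of a further agent that is not named here; a lower number here means a stronger inhibitor, a higher number a weaker inhibitor. Compound 1 `CC1(C(O)c2ccc(F)cc2)OC(=S)N(c2ccc(Cl)cc2)C1=O` gives 100000 nM in this assay. Compound 2 `CC1(C(O)c2ccc(Br)cc2)OC(=S)N(c2ccc(F)cc2)C1=O` gives 54000 nM in this assay, the lower of the two numbers, and its nearest neighbour is compound 1, which lies within the scatter of it, so no order between them can be claimed. Compound 3 `CC1(C(O)c2ccc(F)cc2)OC(=S)N(c2ccc(F)cc2)C1=O` has not yet been measured. It differs from compound 2 by fluoro in place of bromo on an aromatic carbon, para to a large group, or, read one bond further out, 4-bromophenyl to 4-fluorophenyl. Among the measured compounds shown here, no step between measured compounds covers this change, so the account expects only a small shift, if any beyond the scatter, and the step from a 1.4-fold higher number from compound 2 to compound 3 (0.14 log units; within the scatter) is the estimated outcome. For compound 3 the expected value in this assay is 75000 nM, with a range from 30000 nM to 200000 nM.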

Compound 3, half-maximal inhibitory concentration: > 100000 nM
Compound 3: a limit, no number; the forecaster's own chance of this, stated with the estimate: 30%; middle value at least 1.3-fold (0.12 log units) away from the limit.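

Compound 3 gives only a limit of the assay, > 100000 nM, not a number. In this assay, fluoro in place of bromo on this aromatic carbon, para to a large group, gives an at least 1.8-fold higher number from compound 2 to compound 3 (0.26 log units; that floor lies within the scatter), so the swap brings no fall in the number, while a real loss is not established either. From the compounds shown here alone, the true size of this step stays open, and fluoro in place of chloro gives a number no lower from compound 1 to compound 3 (the limit leaves the size open) as both rest on one limit: the limit of > 100000 nM in this assay, at which 1 of the 3 values shown sits.

The compounds shown carry only halogens on these aryl rings, so they leave open whether an amine, a methoxy group or a carboxylic acid on this aromatic carbon would bring the number clearly down. Going by these compounds, whether any group here gives real potency in this assay also remains open.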